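The source may report more compounds than this note shows. Statements on the series, on what has been measured and on what is new or still open speak of the compounds shown alone.

Compound 1 `CC1=CC[C@@H]([C@@](C)(O)CCCC(C)(C)NC=S)CC1`: 90300 nM
Compound 2 `CC1=CC[C@@H]([C@@](C)(O)CCCC(C)(C)NC(=S)NN)CC1`: a limit, > 100000 nM
Compound 3 `COc1ccc(/C=N\NC(=S)NC(C)(C)CCC[C@](C)(O)[C@@H]2CC=C(C)CC2)cc1`: a limit, > 100000 nM

In a functional assay on HT-29 cells (Homo sapiens) for cytotoxicity, read by sulforhodamine B assay (a lower number here means that less compound is tolerated, a higher number that more compound is tolerated), compound 1 gives 90300 nM. Compound 2 reaches only the limit of > 100000 nM. Compound 3 also reaches only the limit of > 100000 nM, so it stands at the edge of what this assay can read. Two of the three values sit there (the limit of > 100000 nM in this assay, at which 2 of the 3 values shown sit). The measured steps give little guidance: an at least 1.1-fold higher number from compound 1 to compound 2 (0.04 log units; that floor lies within the scatter), and a step that the two limits leave unreadable from compound 2 to compound 3. Compound 4 `CC1=CC[C@@H]([C@@](C)(O)CCCC(C)(C)NC(=S)N/N=C\c2ccccc2[N+](=O)[O-])CC1` differs from compound 3 in one place: 2-nitrophenyl in place of 4-methoxyphenyl on a carbon with a double bond to nitrogen. With compound 3 already at the limit, compound 4 is expected to stay near it, a step of a number no higher from compound 3 to compound 4 (the limit leaves the size open), with an estimated 100000 nM between 30000 nM and 200000 nM.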

Compound 4, concentration lethal to 50% of the cells: 44400 nM
Compound 4: the middle estimate sits 2.3-fold (0.35 log units) above what was measured, within the range that was stated.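

In this assay, this change gives an at least 2.2-fold lower number from compound 3 to compound 4 (0.35 log units; beyond the scatter), so the group on a carbon with a double bond to nitrogen can shift how much compound the cells tolerate. Of the two compounds compared here, only compound 4 gives a number, so the step has a floor but no known full size: the limit of > 100000 nM in this assay, at which 2 of the 4 values shown sit.

From the compounds shown here alone, whether gaining 2-nitrophenyl or losing 4-methoxyphenyl drives the shift remains open. A plain phenyl group at this carbon would help separate the two, and how an amine there would behave is also unknown.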